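Metabolic stability notes: nitrile for chloro on compound 1

The source may report more compounds than this note shows. Statements on the series, on what has been measured and on what is new or still open speak of the compounds shown alone.

Going by the values given here, compound 1 `O=[N+]([O-])c1cn2c(n1)OC[C@@H](OCc1ccc(-c3ccc(OC(F)(F)F)cc3)cc1Cl)C2` gives 100% in an ADME assay (liver, Mus musculus, strain CD1) for metabolic stability, using microsomes, with a stated time of 1 h (on this read-out lower numbers stand for a less stable compound and higher numbers for a more stable compound), the highest of the three numbers so far. Compound 2 `O=[N+]([O-])c1cn2c(n1)OC[C@@H](OCc1c(Cl)cc(-c3ccc(OC(F)(F)F)cc3)cc1Cl)C2` gives 93%; the step of a number 7 percentage points lower from compound 1 to compound 2 (within the scatter) lies within the scatter. Compound 3 `O=[N+]([O-])c1cn2c(n1)OC[C@@H](OCc1ccc(-c3ccc(C(F)(F)F)cn3)cc1F)C2` gives 77%, a number beyond the scatter from compound 1. Compound 4 `N#Cc1cc(-c2ccc(OC(F)(F)F)cc2)ccc1CO[C@@H]1COc2nc([N+](=O)[O-])cn2C1` is not yet measured; it differs from compound 1 by cyano in place of chloro on an aromatic carbon. Among the compounds with values here, no measured step exchanges chloro for cyano, so only the general spread of the series bears on it: one step within the scatter, one gap beyond it. For compound 4 a small step down, most likely within the scatter, is expected in this assay, a number 10 percentage points lower from compound 1 to compound 4 (within the scatter). Compound 4 is therefore estimated at 90%, in a range from 70% to 100%.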

Compound 4, percent of the compound remaining: 88%
Beside the measured number, compound 4's estimate is 2 percentage points above it; the measured number falls inside the stated range.
By their numbers in this assay, from the lowest: compound 3; then compounds 4, 2 and 1 (each within the scatter of the next, the first and the last beyond it).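

In this assay, going by these compounds alone, the exchange of chloro for cyano on this aromatic carbon gives a number 12 percentage points lower from compound 1 to compound 4 (beyond the scatter), the one single change from compound 1 here that leaves the scatter, though compound 4 still gives 88%. The other single change, a number 7 percentage points lower from compound 1 to compound 2 (within the scatter), is a replacement of hydrogen and says nothing about replacing chloro. Nothing available gives a reason for the cyano step.

As far as these compounds go, how a methoxy group, an amine or a carboxylic acid on this carbon would read in this assay stays open. From the compounds shown here alone, whether the cyano step repeats with a different group elsewhere on the molecule is also open.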